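The source may hold more compounds than are shown below. What is called first, only, known or untested is meant among the compounds shown, and "the series" means these compounds.

Measured so far in a functional assay on MDA-MB-231 cells (Homo sapiens) for cytotoxicity, read by MTT assay, with a stated time of 72 h; on this read-out lower numbers stand for stronger inhibition and higher numbers for weaker inhibition: compound 1 `CN(C)CCCNc1nc(-c2ccc(NC(=O)Nc3ccc(Cl)cc3)cc2)nc2c(Cl)c(Cl)sc12` gives 1160 nM; compound 2 `CN(C)CCCNc1nc(-c2ccc(NC(=O)Nc3ccc(Cl)cc3Cl)cc2)nc2c(Cl)c(Cl)sc12` gives 3490 nM.

For the measured compounds named here, compound 2 holds the higher of these two numbers, separated from compound 1 by a 3.0-fold higher number from compound 1 to compound 2 (0.48 log units; beyond the scatter), the only step measured. Compound 3 `Cc1ccc(NC(=O)Nc2ccc(-c3nc(NCCCN(C)C)c4sc(Cl)c(Cl)c4n3)cc2)cc1` differs from compound 2 by 4-methylphenyl in place of 2,4-dichlorophenyl on an amide-type nitrogen. The measured step adds a single chloro; the change to compound 3 removes both chlorines and brings in a methyl, so only part of it is covered. Compound 3 is expected to move back toward the number of compound 1, a step of a 2.7-fold lower number from compound 2 to compound 3 (0.43 log units; beyond the scatter) in this assay. Compound 3 is estimated at 1300 nM, within 500 nM to 3500 nM.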

Compound 3, half-maximal inhibitory concentration: 4980 nM
For compound 3 the middle estimate is 3.8-fold (0.58 log units) below the measured one; the measured number lies above the stated range.
By their numbers in this assay, from the lowest: compound 1; then compounds 2 and 3 (each within the scatter of the next).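

In this assay, 4-methylphenyl in place of 2,4-dichlorophenyl on an amide-type nitrogen gives a 1.4-fold higher number from compound 2 to compound 3 (0.15 log units; within the scatter), so this swap leaves no difference that can be read. Methyl in place of chloro on an aromatic carbon gives a 4.3-fold higher number from compound 1 to compound 3 (0.63 log units; beyond the scatter), which shows that adding chloro is not the only change at this position to give a higher number. No measurement offered here accounts for this result. The compounds shown leave open how a methoxy group, a fluoro or a carboxylic acid would read on this aromatic ring in this assay.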